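Pyrrolidine nitrogen variation in a sulfonamide series

This account rests on a few compounds, and the source may have more. Where it says the series, first, only, none or still open, it means among the compounds named here.

Measured compounds:
compound 1, `CC(C)(C)OC(=O)N1CCC[C@H]1C(=O)N1CCC(NS(=O)(=O)c2cc(S(=O)(=O)c3ccccc3)ccc2C(F)(F)F)CC1`, 60 nM
compound 2, `CN(C)CC(=O)N1CCC[C@H]1C(=O)N1CCC(NS(=O)(=O)c2cc(S(=O)(=O)c3ccccc3)ccc2C(F)(F)F)CC1`, 90 nM
compound 3, `CN1CCC[C@H]1C(=O)N1CCC(NS(=O)(=O)c2cc(S(=O)(=O)c3ccccc3)ccc2C(F)(F)F)CC1`, 120 nM

In an assay on isolated protein for binding affinity to secreted frizzled-related protein 1 (Homo sapiens), read by fluorescence (on this read-out lower numbers stand for stronger inhibition and higher numbers for weaker inhibition), compound 1 gives the lowest of the three numbers; its nearest neighbour is compound 2 at a 1.5-fold higher number from compound 1 to compound 2 (0.18 log units; within the scatter) and the furthest is compound 3 at a 2.0-fold higher number from compound 1 to compound 3 (0.30 log units; within the scatter), both within the scatter. Compound 4, `O=C([C@@H]1CCCN1Cc1ccccc1)N1CCC(NS(=O)(=O)c2cc(S(=O)(=O)c3ccccc3)ccc2C(F)(F)F)CC1`, differs from compound 1 by benzyl in place of tert-butoxycarbonyl on an amine nitrogen in a ring. Going by the values given here, the steps that bear on this are the exchanges at the same ring nitrogen, a 2.0-fold higher number from compound 1 to compound 3 (0.30 log units; within the scatter) and a 1.3-fold higher number from compound 2 to compound 3 (0.12 log units; within the scatter), neither beyond the scatter. The pattern so far shows this nitrogen tolerating three quite different groups with no shift beyond the scatter, so no step beyond the scatter is expected for compound 4 in this assay. The expected step is a 1.3-fold higher number from compound 1 to compound 4 (0.12 log units; within the scatter). Compound 4 is estimated at 80 nM, with a range of 35 nM to 200 nM.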

Compound 4, half-maximal inhibitory concentration: 1400 nM
Beside the measured number, compound 4's estimate is 18-fold (1.24 log units) below it; the measured number lies above the stated range.
By their numbers in this assay, from the lowest: compounds 1, 2 and 3 (each within the scatter of the next); then compound 4.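

In this assay, the amine nitrogen in the ring proves sensitive to benzyl (a 23-fold higher number from compound 1 to compound 4 (1.37 log units; beyond the scatter); a 16-fold higher number from compound 2 to compound 4 (1.19 log units; beyond the scatter); a 12-fold higher number from compound 3 to compound 4 (1.07 log units; beyond the scatter)), although tert-butoxycarbonyl, ((dimethylamino)methyl)carbonyl and methyl stay within the scatter of one another. Tert-butoxycarbonyl and benzyl have the same heavy-atom count, so that count does not separate compound 1 from compound 4, and the carbonyl is absent from compound 3 as well as compound 4. Of the groups shown, only benzyl carries an aromatic ring, but no measurement here explains the loss. Still open, going by these compounds, is whether the aromatic ring itself matters, which cyclohexylmethyl on this nitrogen would test. Benzoyl would show whether the same ring is tolerated on a carbonyl.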